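Fluorophenyl for Bromophenyl on a Nitro Chalcone Triazole

The compounds below may be only part of what the source reports. "The series", "measured", "known", "first", "only" and "open" are said of these compounds alone.

Compound 3 `O=C(/C=C/c1ccc(OCc2cn(Cc3cccc(Br)c3)nn2)cc1)c1ccc([N+](=O)[O-])cc1` gives 12% in a functional assay on MCF7 cells (Homo sapiens) for inhibition, read by MTT assay, with a stated time of 48 h, tested at 10 uM (on this read-out lower numbers stand for less inhibition of growth and higher numbers for more inhibition of growth at the one concentration tested), the lower of the two numbers reported. Compound 1 `COc1ccc(C(=O)/C=C/c2ccc(OCc3cn(Cc4ccccc4F)nn3)cc2)cc1` gives 32% in this assay, a number higher than that of compound 3 by a margin beyond the usual scatter. Compound 2 `O=C(/C=C/c1ccc(OCc2cn(Cc3ccccc3)nn2)cc1)c1ccc([N+](=O)[O-])cc1` shares the nitro-bearing ketone of compound 3; in this assay compound 2 gives "not active" (no number reported), without a number. Compound 4 `O=C(/C=C/c1ccc(OCc2cn(Cc3ccccc3F)nn2)cc1)c1ccc([N+](=O)[O-])cc1` differs from compound 3 by 2-fluorophenyl in place of 3-bromophenyl on a saturated chain carbon bound to an aromatic nitrogen. Going by the values given here, no step between measured compounds links these groups directly, so the expected change is small, with no direction beyond the scatter. Compound 1 carries the same 2-fluorophenyl yet a different ketone, and compound 2 shows the nitro ketone can give no activity at all. Compound 4 is therefore estimated at 15%, between 0% and 32%, an expected step of a number 3 percentage points higher from compound 3 to compound 4 (within the scatter).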

Compound 4, percent growth inhibition at one concentration: 33%
Compound 4: middle estimate off by 18 percentage points, on the low side; the whole stated range lies below it.
By their numbers in this assay, from the lowest: compound 3; then compounds 1 and 4 (each within the scatter of the next).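

In this assay, 2-fluorophenyl in place of 3-bromophenyl on a saturated chain carbon bound to an aromatic nitrogen gives a number 21 percentage points higher from compound 3 to compound 4 (beyond the scatter) on the nitro ketone, so the read-out responds to this change at this position. With 2-fluorobenzyl held constant, nitro in place of methoxy on an aromatic carbon gives a number 1 percentage points higher from compound 1 to compound 4 (within the scatter), so this pair does not separate the two ketones. Nothing shown explains either step.

As far as these compounds go, compound 2 gives no number, so whether the halogen itself or its position matters stays open. From the compounds shown here alone, how a pyridine ring or a longer chain would read here also remains unknown.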